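Trading an Amino Link for a Direct Aryl Bond

The source may hold more compounds than are shown below. What is called first, only, known or untested is meant among the compounds shown, and "the series" means these compounds.

Measured compounds:
compound 1, `COc1cc(Cl)cc(-c2nn(-c3cccc(NC(=O)Nc4ccc(Cl)c(C(F)(F)F)c4)c3)cc2-c2ccncc2)c1`, giving 83%
compound 2, `COc1cc(Cl)cc(-c2nn(-c3cccc(NC(=O)Nc4cc(C(F)(F)F)cc(C(F)(F)F)c4)c3)cc2-c2ccncc2)c1`, giving 23%

In a functional assay on UACC-257 cells (Homo sapiens) for inhibition, read by sulforhodamine B assay, with a stated time of 48 h, tested at 1 uM (a higher number here means a weaker effect of the compound at the concentration tested, a lower number a stronger effect), compound 1 gives 83%, the highest of the two numbers, so the weakest effect seen here. Within the data shown here, its nearest neighbour, compound 2, gives 23%, a reading far lower and well beyond the usual scatter, although no single step links the two structures.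

Compound 3, `COc1cc(Cl)cc(-c2nn(-c3cccc(NC(=O)c4cccc(C(F)(F)F)c4)c3)cc2-c2ccncc2)c1`, has not yet been measured in this assay. It differs from compound 1 in one place: 3-(trifluoromethyl)phenyl in place of (4-chloro-3-(trifluoromethyl)phenyl)amino on a carbonyl carbon. The change removes one hydrogen-bond donor and the chlorine that sat on the leaving group, and leaves the carbonyl carbon joined directly to an aromatic ring.

Among the measured compounds shown here, since no measured pair shows this kind of step, the step of a number 5 percentage points higher from compound 1 to compound 3 (within the scatter) is an estimate resting only on compound 1 standing at 83%; a small move upward, or none beyond the scatter, is expected. Compound 3 is therefore expected to read about 88%, within 65% to 105%.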

Compound 3, a percentage reported as activity, at one concentration (the size of the read-out at that concentration, not a potency): 92%
Compound 3: middle estimate off by 4 percentage points, on the low side; measured number inside the range.
By their numbers in this assay, from the lowest: compound 2; then compounds 1 and 3 (each within the scatter of the next).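

In this assay the swap of (4-chloro-3-(trifluoromethyl)phenyl)amino for 3-(trifluoromethyl)phenyl on the carbonyl carbon leaves the reading within the scatter (a number 9 percentage points higher from compound 1 to compound 3 (within the scatter)). At this position, then, the amino link and the chlorine can both be exchanged for a direct aryl bond without a difference that can be told apart from repeat-to-repeat noise. Both compounds still show only a weak effect at the concentration tested, and no measurement at hand explains the result.

On these data alone, this single step removes the amino link and the chlorine together, so the effect of each alone stays open. Also open, as far as these compounds go, is how the reading would respond to a nitrile on this phenyl ring, or to a methylene chain linking the ring to the carbonyl carbon.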